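Carboxycarbonyl in Place of (Trifluoromethyl)sulfonyl on a Receptor Ligand

The source may hold more compounds than are shown below. What is called first, only, known or untested is meant among the compounds shown, and "the series" means these compounds.

Measured so far:
compound 1, `CCCCCCCCCCCCOc1ccc(C[S+]([O-])c2ccc(C(=O)O)cc2)nc1/C=C/C(=O)O`, 252 nM
compound 2, `COc1ccc(CCCCCCCCOc2ccc(CSc3cccc(NS(=O)(=O)C(F)(F)F)c3)nc2/C=C/C(=O)O)cc1`, 284 nM

Of the compounds shown here, two have been measured in an assay for binding affinity to leukotriene B4 receptor 1 (Homo sapiens); a lower number here means a stronger inhibitor, a higher number a weaker inhibitor. Compound 1 gives 252 nM, and compound 2 gives 284 nM. Compound 2 thus has the higher of the two numbers, but its gap to compound 1 lies within the scatter of repeated measurements, so the two cannot be ordered on these data. The two structures differ in several places at once, so nothing beyond the two values themselves can be read from the pair.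

The next compound, compound 3, is `COc1ccc(CCCCCCCCOc2ccc(CSc3cccc(NC(=O)C(=O)O)c3)nc2/C=C/C(=O)O)cc1`. It keeps the whole of compound 2 except for one change: carboxycarbonyl in place of (trifluoromethyl)sulfonyl on a nitrogen on an aromatic ring. Cut one bond further out, the change reads ((trifluoromethyl)sulfonyl)amino to (carboxycarbonyl)amino.

Going by the values given here, no step between measured compounds that isolates this exchange is available, so the expectation rests on the value of compound 2 alone, 284 nM. Compound 3 is estimated to give 350 nM, with a range from 120 nM to 1000 nM. The expected step, a 1.2-fold higher number from compound 2 to compound 3 (0.09 log units; within the scatter), is no larger than the scatter.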

Compound 3, inhibition constant: 72 nM
Compound 3: middle estimate off by 4.9-fold (0.69 log units), on the high side, and the stated range ends above it.
By their numbers in this assay, from the lowest: compound 3; then compounds 1 and 2 (each within the scatter of the next).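

In this assay, going by these compounds alone, the exchange of (trifluoromethyl)sulfonyl for carboxycarbonyl on a nitrogen on an aromatic ring gives a 3.9-fold lower number from compound 2 to compound 3 (0.60 log units; beyond the scatter) and so provides the first step in this set that isolates a single change, showing that the number responds to what sits on this nitrogen. The sulfur-bearing, fluorinated group can be replaced here without any loss, and the series gains a compound that stands beyond the scatter from compound 2. The entering group has fewer heavy atoms and brings a hydrogen-bond donor that the leaving group lacks, but no measurement available here ties the step to either difference or to any other cause.

The compounds shown leave open whether the step depends on the carboxylic acid end of carboxycarbonyl, a question that a methyl ester or a simple acetyl group on the same nitrogen would address. They also leave open whether the same exchange gives a step of similar size when the long chain carrying the methoxy-substituted ring is replaced by a plain dodecyl chain.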